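The source may hold more compounds than are shown below. What is called first, only, known or untested is meant among the compounds shown, and "the series" means these compounds.

Three compounds have been measured in a functional assay on HepG2 cells (Homo sapiens) for cytotoxicity, read by MTT assay, with a stated time of 72 h; a higher number here means a weaker inhibitor, a lower number a stronger inhibitor:

compound 1 `CN1[C@@H]2c3[nH]c4ccccc4c3C[C@H]1[C@H](C#N)N1[C@@H](CNC(=O)c3ccc(Cl)cc3)c3[nH]c4ccccc4c3C[C@@H]21` gives 350 nM
compound 2 `COc1ccc(C(=O)NC[C@H]2c3[nH]c4ccccc4c3C[C@H]3[C@H]4c5[nH]c6ccccc6c5C[C@@H]([C@H](C#N)N23)N4C)cc1` gives 310 nM
compound 3 `CN1[C@@H]2c3[nH]c4ccccc4c3C[C@H]1[C@H](C#N)N1[C@@H](CNC(=O)c3cc4ccccc4s3)c3[nH]c4ccccc4c3C[C@@H]21` gives 300 nM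

Compound 1 has the highest of these three numbers, yet its steps to the others, a 1.1-fold lower number from compound 1 to compound 2 (0.05 log units; within the scatter) and a 1.2-fold lower number from compound 1 to compound 3 (0.07 log units; within the scatter), both lie within the scatter, as does a 1.0-fold lower number from compound 2 to compound 3 (0.01 log units; within the scatter). For the measured compounds named here, in short, nothing among the measured compounds separates them.

Compound 4 `CN1[C@@H]2c3[nH]c4ccccc4c3C[C@H]1[C@H](C#N)N1[C@@H](CNC(=O)c3cc4ccccc4[nH]3)c3[nH]c4ccccc4c3C[C@@H]21` has not yet been measured. It differs from compound 1 in one place: 1H-indol-2-yl in place of 4-chlorophenyl on a carbonyl carbon.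

All three measured steps bear on this change, since each of them alters the group carried by the carbonyl carbon or a substituent on that group, and none of them moved the number beyond the scatter. The step to compound 4 alters the same part of the shared core, so no shift beyond the scatter is expected in this assay either way; the step expected is a 1.1-fold lower number from compound 1 to compound 4 (0.04 log units; within the scatter). Compound 4 is therefore estimated to give about 320 nM, within a range of 150 nM to 700 nM.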

Compound 4, half-maximal inhibitory concentration: 440 nM
Beside the measured number, compound 4's estimate is 1.4-fold (0.14 log units) below it; the measured number falls inside the stated range.
By their numbers in this assay, from the lowest: compounds 3, 2, 1 and 4 (each within the scatter of the next).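

Across the shared core, the carbonyl carbon has now carried four different groups in this assay, and the new steps stay small: a 1.3-fold higher number from compound 1 to compound 4 (0.10 log units; within the scatter) and a 1.5-fold higher number from compound 3 to compound 4 (0.17 log units; within the scatter) and a 1.4-fold higher number from compound 2 to compound 4 (0.15 log units; within the scatter). The new information is that 1H-indol-2-yl, which has a hydrogen-bond donor that 4-chlorophenyl lacks, still leaves compound 4 within the scatter of compounds 1, 2 and 3, so adding this donor on the group does not separate compound 4 from them. No measurement offered here accounts for these small differences.

The compounds shown leave open whether this assay would stay this insensitive if the aromatic group gave way to a carboxylic acid, an amine or a longer alkyl chain. They also leave open whether the same holds in any other cell line.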